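The source may hold more compounds than are shown below. What is called first, only, known or untested is meant among the compounds shown, and "the series" means these compounds.

Measured so far in an ADME assay on S9 fraction from liver (Homo sapiens) for metabolic stability, with a stated time of 1 h; a higher number here means that more of the compound is left, a lower number that less of the compound is left:
- compound 1 `N#Cc1cnc(NCc2ccccc2C(F)(F)F)cc1N[C@H]1CC[C@@H](O)CC1` at 0%
- compound 2 `N#Cc1cnc(NCc2cnccc2C(F)(F)F)cc1NC[C@H]1CC[C@H](O)CC1` at 32%

Of these two, compound 1 has the lower value (0%), and compound 2 (32%) lies above it by more than the usual scatter. The two compounds differ in more than one place, so their values do not isolate any single change.

Compound 3 `N#Cc1cnc(NCc2ccccc2C(F)(F)F)cc1N[C@H]1C[C@@H](C(N)=O)C1` has not yet been measured. It keeps the core of compound 1 and its trifluoromethyl-bearing side, but places 3-carbamoylcyclobutyl in the position of 4-hydroxycyclohexyl on a nitrogen on an aromatic ring (3-carbamoylcyclobutyl in place of 4-hydroxycyclohexyl on a nitrogen on an aromatic ring). Among the measured compounds shown here, no measured pair shows what this swap does, so any forecast remains loose. An upward move is expected, or none beyond the scatter, since compound 1 gives 0% and the share remaining cannot fall further. The expected step is a number 22 percentage points higher from compound 1 to compound 3 (beyond the scatter) in this assay and it is only a rough estimate. For compound 3 the estimated value is 22% with an expected range from 0% to 55% in this read-out.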

Compound 3, percent of the compound remaining: 86%
Compound 3: middle estimate off by 64 percentage points, on the low side; measured number above the stated range.
By their numbers in this assay, from the lowest: compound 1; then compound 2; then compound 3.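

Among the compounds shown here, this step gives the first comparison in which only one place differs. With the core of compound 1 and its trifluoromethyl-bearing side kept, 3-carbamoylcyclobutyl in place of 4-hydroxycyclohexyl on a nitrogen on an aromatic ring gives, in this assay, a number 86 percentage points higher from compound 1 to compound 3 (beyond the scatter), showing that this position alone can move the read-out by a large amount, which the earlier pair, differing in more than one place, could not isolate. Nothing measured here explains the step.

The swap changes the ring and its substituent together, from a six-membered ring carrying a hydroxy group to a four-membered ring carrying a carbamoyl group, so the compounds shown do not separate the contribution of each; a 3-hydroxycyclobutyl or a 4-carbamoylcyclohexyl group on this nitrogen would be needed to do so. On these data alone, it also remains open whether a carboxylic acid or a primary amine in place of the carbamoyl group would keep the value of compound 3 86%, and whether the same swap would give a similar step on the other side chain of compound 2.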